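A few compounds are considered here, and "the series" means these few. Any claim that something is new, unique, unknown or untested is made for them only; others in the source may bear on it.

Measured compounds:
Compound 1 `CC(C)CCn1nc(-c2cccs2)c(O)c(C2=NS(=O)(=O)c3cc(O)ccc3N2)c1=O` gives 0.0933 h in an in vitro ADME assay on microsomes from liver (Homo sapiens) for metabolic stability, tested at 5 uM; a higher number here means that the compound lasts longer, a lower number that the compound disappears faster.
Compound 2 `CC(C)CCn1nc(-c2cccs2)c(O)c(C2=NS(=O)(=O)c3cc(OCC(N)=O)ccc3N2)c1=O` gives 0.383 h in this assay.
Compound 3 `CC(C)CCn1nc(-c2cccs2)c(O)c(C2=NS(=O)(=O)c3cc(OC(C)C(N)=O)ccc3N2)c1=O` gives 0.217 h in this assay.

Compound 3 stands second highest of the three numbers in this assay. Its nearest neighbour is compound 2, from which it differs by a methyl on the chain carbon: a 1.8-fold lower number from compound 2 to compound 3 (0.25 log units; within the scatter). Its furthest neighbour is compound 1: a 2.3-fold higher number from compound 1 to compound 3 (0.37 log units; beyond the scatter). The largest step among the three is a 4.1-fold higher number from compound 1 to compound 2 (0.61 log units; beyond the scatter).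

Compound 4 `CC(C)CCn1nc(-c2cccs2)c(O)c(C2=NS(=O)(=O)c3cc(OC(C)(C)C(N)=O)ccc3N2)c1=O` differs from compound 3 in one place: methyl in place of hydrogen on a saturated chain carbon bound to a carbonyl carbon, an oxygen on an aromatic ring and a saturated chain carbon. The step that bears most directly on this change is the earlier one at the same carbon, a 1.8-fold lower number from compound 2 to compound 3 (0.25 log units; within the scatter), which stayed within the scatter. The two steps from compound 1 both concern the substituent on the aromatic oxygen itself and give no further guidance on a second methyl at this chain carbon. Among the compounds with values here, with only one relevant step, and that one within the scatter, the expected step is also within the scatter: a 1.1-fold lower number from compound 3 to compound 4 (0.04 log units; within the scatter). Compound 4 is therefore estimated at 0.2 h in this assay, with a range from 0.1 h to 0.45 h.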

Compound 4, half-life: 0.35 h
Compound 4: middle estimate off by 1.8-fold (0.24 log units), on the low side; measured number inside the range.
By their numbers in this assay, from the lowest: compound 1; then compounds 3, 4 and 2 (each within the scatter of the next).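

In this assay the second methyl on the saturated chain carbon bound to a carbonyl carbon, an oxygen on an aromatic ring and a saturated chain carbon gives a 1.6-fold higher number from compound 3 to compound 4 (0.21 log units; within the scatter) and so leaves no step beyond the scatter, and the comparison with the unmethylated chain, a 1.1-fold lower number from compound 2 to compound 4 (0.04 log units; within the scatter) as 1-carbamoyl-1-methylethyl replaces carbamoylmethyl, also stays within it. Carbamoylmethyl, 1-carbamoylethyl and 1-carbamoyl-1-methylethyl therefore cannot be told apart here, whether this carbon carries no methyl, one or two, and the fully substituted carbon keeps the distance from the free hydroxyl of the parent, a 3.8-fold higher number from compound 1 to compound 4 (0.57 log units; beyond the scatter) beyond the scatter, as the two earlier groups did. Nothing shown here gives a reason for these numbers or for the lasting difference from compound 1.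

The compounds shown leave open whether the carbamoyl part of these groups matters at all, as a carboxylic acid or a plain methyl ether on the same oxygen would test. They also leave open what a longer chain, such as an ethyl on this carbon or a cyclopropane ring built on it, would do to the half-life.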